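The compounds below may be only part of what the source reports. "The series", "measured", "known", "first", "only" and "open" are said of these compounds alone.

Measured compounds in this series:

Compound 1 `Cc1ccc(-n2nncc2CN2C(=O)C3(C(C#N)=C(N)Oc4c3c3nc5ccccc5nc3c3ccccc43)c3ccccc32)cc1C`: in an ADME assay on L02 cells (Homo sapiens) for antiproliferative activity, read by MTT assay, with a stated time of 48 h (a lower number here means a stronger inhibitor, a higher number a weaker inhibitor), compound 1 gives > 50000 nM, a limit of the assay rather than a number.
Compound 2 `Cc1ccc(-n2nncc2CN2C(=O)C3(C(C#N)=C(N)Oc4c3c3nc5ccccc5nc3c3ccccc43)c3ccccc32)c(C)c1`: in this assay compound 2 gives > 50000 nM, again a limit.
Compound 3 `N#CC1=C(N)Oc2c(N)cc3nc4ccccc4nc3c2C12C(=O)N(Cc1cnnn1-c1ccc(Cl)cc1)c1ccccc12`: in this assay compound 3 gives > 50000 nM, also a limit.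

Compound 3 therefore stands at the limit of > 50000 nM in this assay, at which 3 of the 3 values shown sit, and nothing shown separates it from the other two, since every value so far is a limit. Going by the values given here, the one step that can be set between measured compounds, a step that the two limits leave unreadable from compound 1 to compound 2, is unreadable, and it concerns a different position of the shared core in any case.

The next compound, compound 4 `N#CC1=C(N)Oc2c(N)cc3nc4ccccc4nc3c2C12C(=O)N(Cc1cnnn1-c1ccc([N+](=O)[O-])cc1)c1ccccc12`, differs from compound 3 as follows: nitro in place of chloro on an aromatic carbon. Among the compounds with values here, no measured step bears on nitro in place of chloro at that position, so no direction or size can be read for it. The step from compound 3 to compound 4 is expected to remain unreadable, in the sense of a step that the limit leaves unreadable from compound 3 to compound 4, with compound 4 most likely reported as a limit again. Compound 4 is expected to give about 80000 nM, in a range from 25000 nM to 300000 nM.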

Compound 4, half-maximal inhibitory concentration: > 50000 nM
Compound 4: a limit, no number; the forecaster's own chance of this, stated with the estimate: 85%; the middle value lies beyond the limit too.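

No new step can be read from compound 3 to compound 4, since both values are limits and not numbers: the limit of > 50000 nM in this assay, at which 4 of the 4 values shown sit.

The compounds shown leave open how far each lies past that limit, and whether 4-chlorophenyl to 4-nitrophenyl changes the read-out at all.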